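The source may report more compounds than this note shows. Statements on the series, on what has been measured and on what is new or still open speak of the compounds shown alone.

Measured so far in an ADME assay on HEK293 cells (Homo sapiens) for cytotoxicity, read by CCK-8 assay and cell counting, with a stated time of 2 days; on this read-out higher numbers stand for weaker inhibition and lower numbers for stronger inhibition:
Compound 1, `Oc1ccc(-c2cc(-c3cccc(Cl)c3)nc(-c3ccccn3)c2)cc1`, gives 25400 nM.
Compound 2, `Oc1ccc(-c2cc(-c3cccnc3)nc(-c3cccc(Cl)c3)c2)cc1`, gives 25700 nM.
Compound 3, `Oc1ccc(-c2cc(-c3ccccc3)nc(-c3ccc(Cl)cc3)c2)cc1`, gives 4810 nM.

Compound 3 stands lowest of the three numbers; the gap to compound 1 and the gap to compound 2 both lie beyond the usual scatter. Compound 4, `Oc1ccc(-c2cc(-c3ccccc3)nc(-c3cccc(Cl)c3)c2)cc1`, differs from compound 3 by 3-chlorophenyl in place of 4-chlorophenyl on an aromatic carbon.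

Among the measured compounds shown here, only one measured step is available, a 1.0-fold higher number from compound 1 to compound 2 (0.01 log units; within the scatter), and it moves a ring nitrogen rather than a chlorine, so it bears on the present change only loosely; it shows that shifting an attachment point within a ring left this assay unchanged. For the measured compounds named here, compounds 1 and 2, which both carry the 3-chlorophenyl group, give higher numbers than compound 3, but they also differ from compound 3 elsewhere, so no clean step for the chlorine shift exists. The expectation for compound 4 is therefore a small rise, with a step of a 1.6-fold higher number from compound 3 to compound 4 (0.19 log units; within the scatter) considered the likely outcome. For compound 4 the estimated value is 7500 nM, expected to fall between 2500 nM and 22000 nM.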

Compound 4, half-maximal inhibitory concentration: 2820 nM
For compound 4 the middle estimate is 2.7-fold (0.42 log units) above the measured one; the measured number falls inside the stated range.
By their numbers in this assay, from the lowest: compounds 4 and 3 (each within the scatter of the next); then compounds 1 and 2 (each within the scatter of the next).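

In this assay the exchange of 4-chlorophenyl for 3-chlorophenyl on the carbon next to the ring nitrogen gives a 1.7-fold lower number from compound 3 to compound 4 (0.23 log units; within the scatter) and so separates the two chlorine placements no further than the scatter allows. With 3-chlorophenyl held fixed, phenyl in place of pyridin-3-yl gives a 9.1-fold lower number from compound 2 to compound 4 (0.96 log units; beyond the scatter) and phenyl in place of pyridin-2-yl gives a 9.0-fold lower number from compound 1 to compound 4 (0.95 log units; beyond the scatter) so the two steps beyond the scatter here come from the ring exchanged at the other position, not from the chlorine shift. Nothing available accounts for these steps.

Still open, as far as these compounds go, is whether the pyridin-2-yl and pyridin-3-yl steps would hold alongside 4-chlorophenyl. Also open, from the compounds shown here alone, is how this assay responds when an amine or a carboxylic acid takes the place of the chlorine.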